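Swapping the five-membered ring on a hydrolase inhibitor

The source may report more compounds than this note shows. Statements on the series, on what has been measured and on what is new or still open speak of the compounds shown alone.

Measured compounds in an assay on isolated protein for inhibition of ubiquitin carboxyl-terminal hydrolase 7 (Homo sapiens), with stated times of 30 min and 2 h; on this read-out lower numbers stand for stronger inhibition and higher numbers for weaker inhibition:
Compound 1 `CC(C)NCc1ccc(-c2c3ncn(CC4(O)CCN(Cc5ccc(-c6ccco6)cc5Cl)CC4)c(=O)c3nn2C)cc1` gives 29.1 nM.
Compound 2 `Cn1nc2c(=O)n(CC3(O)CCN(Cc4ccc(-c5cnco5)cc4Cl)CC3)cnc2c1-c1ccc(CN)cc1` gives 71.6 nM.
Compound 3 `Cn1nc2c(=O)n(CC3(O)CCN(Cc4ccc(-c5ccco5)cc4Cl)CC3)cnc2c1-c1ccc(Cl)cc1` gives 143 nM.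

Compound 2 holds the second highest of the three numbers; its gap to compound 3 lies within the scatter, while compound 1 sits beyond the scatter at a lower number. Compound 4 `Cn1nc2c(=O)n(CC3(O)CCN(Cc4ccc(-c5ccc[nH]5)cc4Cl)CC3)cnc2c1-c1ccc(CN)cc1` differs from compound 2 by 1H-pyrrol-2-yl in place of 1,3-oxazol-5-yl on an aromatic carbon. Going by the values given here, the only measured single-site step, a 4.9-fold higher number from compound 1 to compound 3 (0.69 log units; beyond the scatter), concerns the group on the other aromatic ring and does not touch this five-membered ring, so no measured step bears directly on the change. The expected step of a 1.0-fold lower number from compound 2 to compound 4 (0.01 log units; within the scatter) is therefore none beyond the scatter. Compound 4 is estimated at 70 nM, with a range from 30 nM to 170 nM.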

Compound 4, half-maximal inhibitory concentration: 193 nM
Estimate against measurement, compound 4: 2.8-fold (0.44 log units) below; the measured number lies above the stated range.
By their numbers in this assay, from the lowest: compound 1; then compounds 2, 3 and 4 (each within the scatter of the next, the first and the last beyond it).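

This five-membered ring is not a silent position: with the rest of the molecule unchanged, the swap gives a 2.7-fold higher number from compound 2 to compound 4 (0.43 log units; beyond the scatter) in this assay. It is the first step shown at this ring, since the earlier single-place step concerned the group on the other aromatic ring. Nothing available explains the shift.

As far as these compounds go, it remains open where a phenyl or 1,3-thiazol-5-yl group on this carbon would fall, and whether the same swap gives a similar step alongside the (isopropylamino)methyl group of compound 1.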